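Sulfonamide in place of sulfone on the shared core

The compounds below may be only part of what the source reports. "The series", "measured", "known", "first", "only" and "open" are said of these compounds alone.

Compound 2 `Cn1c(=O)c(S(=O)(=O)Cc2ccc(F)cc2F)cc2cnc(Nc3ccc4[nH]ccc4c3)nc21` gives 1000 nM in a functional assay on K562 cells (Homo sapiens) for inhibition, read by trypan blue exclusion, with a stated time of 72 h (a lower number here means a stronger inhibitor, a higher number a weaker inhibitor), the lowest of the three numbers measured. Compound 1 `Cn1c(=O)c(S(=O)(=O)c2ccc(F)cc2)cc2cnc(Nc3ccc4occc4c3)nc21` gives 5000 nM in this assay, and compound 3 `Cn1c(=O)c(S(=O)(=O)c2ccc(F)cc2)cc2cnc(Nc3ccc4[nH]ncc4c3)nc21` gives 10000 nM; both gaps from compound 2 lie beyond the scatter, so compound 2 stands as the strongest inhibitor of the three. Compound 4 `Cn1c(=O)c(S(=O)(=O)Nc2ccc(F)cc2)cc2cnc(Nc3ccc4[nH]ccc4c3)nc21` has not been measured. It differs from compound 2 in one place: (4-fluorophenyl)amino in place of 2,4-difluorobenzyl on a sulfonyl sulfur.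

Within the data shown here, the only step measured between compounds that differ in one place is the exchange of the amine substituent a 2.0-fold higher number from compound 1 to compound 3 (0.30 log units; within the scatter), which touches a different part of the molecule and says nothing about the group on the sulfonyl sulfur. Compounds 1 and 2 differ both at the sulfonyl sulfur and at the amine, so their values cannot be split into a single change. Among the measured compounds shown here, no measured step therefore bears directly on the change from compound 2 to compound 4, and the expectation rests on compound 2 alone.

Compound 4 is expected to give 2000 nM in this assay, between 700 nM and 6000 nM, the step of a 2.0-fold higher number from compound 2 to compound 4 (0.30 log units; within the scatter) being a modest expected weakening without a measured precedent.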

Compound 4, half-maximal inhibitory concentration: 5000 nM
Beside the measured number, compound 4's estimate is 2.5-fold (0.40 log units) below it; measured number inside the range.
By their numbers in this assay, from the lowest: compound 2; then compounds 1, 4 and 3 (each within the scatter of the next).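

The group on the sulfonyl sulfur clearly matters in this assay: with everything else held fixed, (4-fluorophenyl)amino in place of 2,4-difluorobenzyl gives a 5.0-fold higher number from compound 2 to compound 4 (0.70 log units; beyond the scatter). Among these compounds, the only earlier step between compounds differing in one place, a 2.0-fold higher number from compound 1 to compound 3 (0.30 log units; within the scatter), concerned the group on a nitrogen on an aromatic ring and said nothing about this position. Both groups carry one six-membered aromatic ring of carbon only, so the step arises while that ring is retained, although one fluorine leaves and a nitrogen and a hydrogen-bond donor enter, and no measurement here ties the step to any one of these differences.

The compounds shown leave open whether the nitrogen or the lost fluorine accounts for the step, as the two change together here; a (2,4-difluorophenyl)amino group or a 4-fluorobenzyl group on the same sulfonyl sulfur would separate them. Also open, going by these compounds, is how a plain alkyl chain or a saturated cyclic amine would read at this position, and whether the step holds when the group on the aromatic amine nitrogen is different.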